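A few compounds are considered here, and "the series" means these few. Any claim that something is new, unique, unknown or untested is made for them only; others in the source may bear on it.

In a functional assay on PC-3 cells (Homo sapiens) for inhibition (on this read-out higher numbers stand for weaker inhibition and lower numbers for stronger inhibition), three compounds have been measured so far. Compound 1 (`CC(/C=C/C(=O)NO)=C\c1ccccc1`) gives 100000000 nM, the highest number of the three and so the weakest inhibition among them. Compound 2 (`O=C(CCCC1CCCCC1)NO`) is the nearest at 20000000 nM, while compound 3 (`CN(O)C(=O)/C=C/c1ccccc1`) is the furthest at 4350000 nM, and both gaps lie beyond the scatter.

Compound 4 (`O=C(/C=C/C=C/c1ccccc1)NO`) has not yet been measured. It differs from compound 1 by hydrogen in place of methyl on a double-bonded chain carbon bound to two double-bonded chain carbons. Going by the values given here, no measured pair shows what such a change does, so the expectation rests only on the spread of the three values. Compound 1 sits at the top of that spread and compound 3 marks its lower end at 4350000 nM, so a moderate move towards stronger inhibition is expected in this assay. The expected step, a 5.0-fold lower number from compound 1 to compound 4 (0.70 log units; beyond the scatter), would lie beyond the scatter. Compound 4 is estimated at 20000000 nM, with an expected range of 3000000 nM to 100000000 nM.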

Compound 4, half-maximal inhibitory concentration: 173000000 nM
Compound 4: the middle estimate sits 8.7-fold (0.94 log units) below what was measured; the measured number lies above the stated range.
By their numbers in this assay, from the lowest: compound 3; then compound 2; then compounds 1 and 4 (each within the scatter of the next).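

Going by these compounds alone, the first measured pair for this position shows a 1.7-fold higher number from compound 1 to compound 4 (0.24 log units; within the scatter) in this assay when hydrogen stands in place of methyl on a double-bonded chain carbon bound to two double-bonded chain carbons. On this read-out, methyl and hydrogen at this place therefore cannot be told apart, a finding that applies to this one pair and the core of compound 1. No available evidence bears on this result.

As far as these compounds go, whether a longer chain such as ethyl, or an amine, at the same place would give a step beyond the scatter remains open. From the compounds shown here alone, it is also open whether the same exchange of methyl for hydrogen would leave the number within the scatter on a different core.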